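From 4-methoxypiperidin-1-yl to piperidin-1-yl in compound 4

The compounds below may be only part of what the source reports. "The series", "measured", "known", "first", "only" and "open" are said of these compounds alone.

Values measured in a functional assay on HGC-27 cells (Homo sapiens) for antiproliferative activity, read by MTT assay, with stated times of 72 h and 4 h; on this read-out higher numbers stand for weaker inhibition and lower numbers for stronger inhibition
compound 1 `COc1ncc(-c2cc3c(N4CCCCC4)ncnc3s2)cc1NS(=O)(=O)c1ccc(F)cc1F` gives 1200 nM
compound 2 `COc1ncc(-c2nc3c(N4CC(C)OC(C)C4)ncnc3s2)cc1NS(=O)(=O)c1ccc(F)cc1F` gives 270 nM
compound 3 `COc1ncc(-c2nc3c(N4CCC(OC)CC4)ncnc3s2)cc1NS(=O)(=O)c1ccc(F)cc1F` gives 74 nM

Compound 3 has the lowest number of the three, clearly apart from both others. Compound 4 `COc1ncc(-c2nc3c(N4CCCCC4)ncnc3s2)cc1NS(=O)(=O)c1ccc(F)cc1F` has hydrogen in place of methoxy on a saturated ring carbon and so carries piperidin-1-yl. For the measured compounds named here, the one measured change of this group is a 3.6-fold lower number from compound 2 to compound 3 (0.56 log units; beyond the scatter) and it is modest. Compound 1 also carries piperidin-1-yl, on a different core, and gives 1200 nM as a loose reference only. A modest move towards a higher number is therefore expected in this assay here. The estimate is a 2.2-fold higher number from compound 3 to compound 4 (0.33 log units; beyond the scatter) for this change. In this assay the estimate for compound 4 is 160 nM with an expected range from 50 nM to 500 nM overall.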

Compound 4, half-maximal inhibitory concentration: 960 nM
The estimate for compound 4 lay 6.0-fold (0.78 log units) below the measured number; the measured number lies above the stated range.
By their numbers in this assay, from the lowest: compound 3; then compound 2; then compounds 4 and 1 (each within the scatter of the next).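

In this assay, for the compounds shown here, the methoxy on the saturated ring carbon proves to matter far more than the earlier compounds could show: its loss gives a 13-fold higher number from compound 3 to compound 4 (1.11 log units; beyond the scatter). Placing piperidin-1-yl in place of 2,6-dimethylmorpholin-4-yl gives a 3.6-fold higher number from compound 2 to compound 4 (0.55 log units; beyond the scatter), so on the shared core the unsubstituted ring has the highest number of the three. Nothing available accounts for these steps.

As far as these compounds go, whether a hydroxy group, an ethoxy group or an amine on that ring carbon would keep the number of compound 3 remains open.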